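Aryl replacement at the core periphery: cytotoxicity working notes

The source may report more compounds than this note shows. Statements on the series, on what has been measured and on what is new or still open speak of the compounds shown alone.

Measured compounds:
compound 1 `COc1cccc(CNCCCNc2ccnc3cc(-c4cccc5ccccc45)ccc23)c1O` — 2520 nM
compound 2 `COc1cccc(CNCCCNc2ccnc3cc(Cc4cc(C)cc(C)c4)ccc23)c1O` — 2680 nM

In an ADME assay on HepG2 cells (Homo sapiens) for cytotoxicity, read by luminescence, CellTiter-Glo and ATP content, with a stated time of 72 h (a lower number here means that less compound is needed, a higher number that more compound is needed for the effect), compound 1 gives 2520 nM, and compound 2 gives 2680 nM. The one step so far, a 1.1-fold higher number from compound 1 to compound 2 (0.03 log units; within the scatter), lies within the scatter, so compound 2 and compound 1 sit at the same level on the numbers shown and neither can be set above the other.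

Compound 3 `COc1ccccc1Oc1ccc2c(NCCCNCc3cccc(OC)c3O)ccnc2c1` is not yet measured in this assay. It differs from compound 2 by 2-methoxyphenoxy in place of 3,5-dimethylbenzyl on an aromatic carbon. For the measured compounds named here, the only step that bears on it is the aryl exchange at the same place, a 1.1-fold higher number from compound 1 to compound 2 (0.03 log units; within the scatter), which produced no movement beyond the scatter. Going by the values given here, the entering group carries two hydrogen-bond acceptors where the leaving one has none, and no measured pair tests that; the expectation therefore rests on the one neutral step. For compound 3 the expected step is a 1.0-fold lower number from compound 2 to compound 3 (0.01 log units; within the scatter), none beyond the scatter. Compound 3 is estimated at 2600 nM, with a range from 1100 nM to 6200 nM.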

Compound 3, half-maximal effective concentration: 11200 nM
Compound 3: the middle estimate sits 4.3-fold (0.63 log units) below what was measured; measured number outside the range, above it.
By their numbers in this assay, from the lowest: compounds 1 and 2 (each within the scatter of the next); then compound 3.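

At this aromatic carbon of the shared core, the group is not indifferent in this assay: 2-methoxyphenoxy gives a 4.2-fold higher number from compound 2 to compound 3 (0.62 log units; beyond the scatter) and, against naphthalen-1-yl, a 4.4-fold higher number from compound 1 to compound 3 (0.65 log units; beyond the scatter) while the earlier exchange of two carbon-only aryl groups stayed within the scatter. The step from 3,5-dimethylbenzyl keeps the heavy-atom count and the single six-membered aromatic ring, and it changes carbon for oxygen and adds hydrogen-bond acceptors, so the first clear movement at this place comes with oxygen-bearing substitution, seen here in compound 3 alone. Nothing at hand speaks to the cause of this movement.

One group cannot separate the ether oxygen at the core from the methoxy group on the ring: unsubstituted phenoxy and 2-methoxybenzyl at this place would pull the two apart. Going by these compounds, whether an amine or a carboxylic acid on the same carbon would shift the number, and in which direction, also remains open.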